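This account rests on a few compounds, and the source may have more. Where it says the series, first, only, none or still open, it means among the compounds named here.

Measured compounds:
Compound 1 `Cc1nc(N)c2c(-c3ccoc3)cn([C@@H]3O[C@H](CO)[C@@H](O)[C@H]3O)c2n1` gives > 20000 nM in a functional assay on CEM-DNR-bulk cells (Homo sapiens), read by MTT assay, with a stated time of 72 h (on this read-out lower numbers stand for stronger inhibition and higher numbers for weaker inhibition), a limit of the assay and not a number.
Compound 2 `CNc1ncnc2c1c(-c1ccsc1)cn2[C@@H]1O[C@H](CO)[C@@H](O)[C@H]1O` gives > 20000 nM in this assay, again a limit rather than a number.
Compound 3 `Cc1nc(N)c2c(-c3ccsc3)cn([C@@H]3O[C@H](CO)[C@@H](O)[C@H]3O)c2n1` gives > 20000 nM in this assay, again only a limit.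

All three values therefore sit at the limit of this assay, which is what the limit of > 20000 nM in this assay, at which 3 of the 3 values shown sit, records. Compound 3 and compound 1 differ by furan-3-yl in place of thiophen-3-yl on an aromatic carbon; the step that the two limits leave unreadable from compound 3 to compound 1 cannot be read, as both ends are limits. Compound 2 and compound 3 have the same atoms joined differently, and the difference between the two cores is not broken down here.

Compound 4 `CNc1ncnc2c1c(-c1ccoc1)cn2[C@@H]1O[C@H](CO)[C@@H](O)[C@H]1O` has not yet been measured. Within the data shown here, it differs from compound 2 by furan-3-yl in place of thiophen-3-yl on an aromatic carbon, the same change at the same place as the one from compound 3 to compound 1. Among the measured compounds shown here, nothing among the measured compounds shows this change moving a value off the limit. The step expected here, a step that the limit leaves unreadable from compound 2 to compound 4, is estimated to be small, resting on (the limit of > 20000 nM in this assay, at which 3 of the 3 values shown sit). Compound 4 is accordingly estimated at about 30000 nM in this assay, expected between 10000 nM and 100000 nM, most likely reported again only as a limit.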

Compound 4, half-maximal inhibitory concentration: > 20000 nM
Compound 4 gave a limit, no number; the forecaster's own chance of this, stated with the estimate: 85%; the middle value lies beyond the limit too.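

Compound 2 and compound 4 both stand at a limit of this assay rather than at a number, so the change from thiophen-3-yl to furan-3-yl gives no readable step between them. The compounds shown leave open whether these two groups, or the two cores, differ at all in this assay, as every value stands at one limit: the limit of > 20000 nM in this assay, at which 4 of the 4 values shown sit.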